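From compound 2 to compound 3: one regrouped side chain

The source may report more compounds than this note shows. Statements on the series, on what has been measured and on what is new or still open speak of the compounds shown alone.

- Compound 1 `C#CCNC(=O)c1cccc2c1cc(C)n2-c1nc2c(c(NCc3ccccc3)n1)CCCC2` gives > 24 h as a limit
- Compound 2 `C#CCNC(=O)c1cccc2c1cc(C)n2-c1nc2c(c(NCc3ccccc3)n1)COCC2` gives > 24 h as a limit

In a physicochemical assay for pharmacokinetics, read by LC-MS, in phosphate buffer, tested at 1 uM (a higher number here means that the compound lasts longer, a lower number that the compound disappears faster), compound 2 gives > 24 h as a limit, not a number. Among the measured compounds shown here, the series so far shows the limit of > 24 h in this assay, at which 2 of the 2 values shown sit, and nothing more. For the measured compounds named here, compound 3 `CC#CC(=O)Nc1cccc2c1cc(C)n2-c1nc2c(c(NCc3ccccc3)n1)COCC2` carries ((prop-1-yn-1-yl)carbonyl)amino in place of propargylcarbamoyl on an aromatic carbon as its single change. No measured step sizes this change. An estimated step of a number no higher from compound 2 to compound 3 (the limit leaves the size open) is expected, with no shift beyond the scatter. For compound 3 the estimate is 24 h within an expected range of 12 h to 48 h in this series.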

Compound 3, half-life: 16.2 h
The estimate for compound 3 lay 1.5-fold (0.17 log units) above the measured number; the measured number falls inside the stated range.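

Among the compounds shown here, compound 3 gives the first number rather than a limit in this assay, at 16.2 h. Compound 2 gives > 24 h, which is a limit and not a number. Regrouping propargylcarbamoyl as ((prop-1-yn-1-yl)carbonyl)amino on this aromatic carbon gives an at least 1.4-fold lower number from compound 2 to compound 3 (0.17 log units; that floor lies within the scatter), so this position now has a first step, though only as a floor.

On these data alone, the true size of this step stays open because of the limit: the limit of > 24 h in this assay, at which 2 of the 3 values shown sit. As far as these compounds go, how a simple amine or a carboxylic acid on the same aromatic carbon would read in this assay also remains open.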